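The source may hold more compounds than are shown below. What is called first, only, known or untested is meant among the compounds shown, and "the series" means these compounds.

Three compounds have been measured in an assay on CHO cells for displacement of a labelled ligand from adenosine receptor A3 (Homo sapiens), read by scintillation counting, tested at 10 uM; on this read-out lower numbers stand for less inhibition and higher numbers for more inhibition at the one concentration tested (going by the name of the read-out):

Compound 1, `CC(C)(C)Cc1c(-c2c(F)cccc2F)sc(N)c1C(=O)c1ccc(Cl)cc1`: 1%
Compound 2, `Cc1ccc(-c2sc(N)c(C(=O)c3ccc(Cl)cc3)c2CC(C)(C)C)cc1`: 1%
Compound 3, `Cc1cccc(-c2sc(N)c(C(=O)c3ccc(Cl)cc3)c2CC(C)(C)C)c1`: 1%

All three share one core and differ only in the aromatic ring that hangs from it. Compound 3 stands level with the other two: no change at the digits printed from compound 1 to compound 3 (within the scatter), and no change at the digits printed from compound 2 to compound 3 (within the scatter). The remaining pair behaves the same way, no change at the digits printed from compound 1 to compound 2 (within the scatter). In short, swapping 2,6-difluorophenyl for 4-methylphenyl or for 3-methylphenyl, or moving the methyl from one position of the ring to another, has left this assay unmoved.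

Compound 4, `CC(C)(C)Cc1c(-c2ccccc2)sc(N)c1C(=O)c1ccc(Cl)cc1`, is the next step from compound 3. The change is hydrogen in place of methyl on an aromatic carbon, so the methyl is simply removed from the 3-methylphenyl ring to leave phenyl. Going by the values given here, no measured step removes a methyl in this way, but all three measured steps alter the same ring and none of them moved the read-out beyond the scatter. On that basis the expected step is no change at the digits printed from compound 3 to compound 4 (within the scatter), that is, no change beyond the scatter. Compound 4 is therefore expected to give 1% in this assay, with a range from 0% to 10%.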

Compound 4, a percentage reported as inhibition, at one concentration (the size of the read-out at that concentration, not a potency): 1%
Compound 4: middle estimate and measured number agree at the digits printed, within the range that was stated.
By their numbers in this assay, from the lowest: compounds 1, 2, 3 and 4 (each within the scatter of the next).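

Compound 4 carries a bare phenyl ring, which adds the unsubstituted case at this position in this assay. Taking away the methyl leaves the reading flat whichever ring position it held (no change at the digits printed from compound 3 to compound 4 (within the scatter); no change at the digits printed from compound 2 to compound 4 (within the scatter)), and so does replacing 2,6-difluorophenyl with phenyl (no change at the digits printed from compound 1 to compound 4 (within the scatter)), so all four compounds, with or without these small groups on the ring, sit close to no inhibition at the one concentration tested. No supporting measurement is available to explain this flat result.

Because the reading is already so close to none, these compounds cannot show whether a small change on this ring could lower it, only that methyl, fluorine and hydrogen do not raise it beyond the usual scatter. Going by these compounds, it remains open whether a larger or very different group, such as an amine or a carboxylic acid on the ring, or a longer chain in place of the ring, would lift the reading, and whether changes elsewhere on the shared core would do so.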